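Swapping a Cyclohexyl for an Amide on a Fused Core

A few compounds are considered here, and "the series" means these few. Any claim that something is new, unique, unknown or untested is made for them only; others in the source may bear on it.

In an assay on HEK293 cells for positive allosteric modulation of metabotropic glutamate receptor 5 (Homo sapiens), read by FLIPR, with a stated time of 1 h (on this read-out lower numbers stand for an effect already at smaller amounts and higher numbers for an effect only at larger amounts of compound), two close relatives sharing the same fused core have been measured so far. Compound 1 `Fc1cccc(C#Cc2nc3c(s2)CN(C2CCOC2)CC3)c1` gives > 10000 nM, which is a limit of the assay rather than a number. Compound 2 `C(#Cc1nc2c(s1)CN(C1CCCCC1)CC2)c1ccccc1` likewise gives > 10000 nM, again only a limit. Both measured values thus sit at the same edge, (the limit of > 10000 nM in this assay, at which 2 of the 2 values shown sit), so nothing separates compound 2 from compound 1 on the numbers shown.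

Compound 3 `O=C(C1CCCO1)N1CCc2nc(C#Cc3ccccc3)sc2C1` has not yet been measured. It differs from compound 2 in one place: (oxolan-2-yl)carbonyl in place of cyclohexyl on an amine nitrogen in a ring. No measured step of this kind exists among the compounds shown, so the only anchor is that compound 2 and compound 1 both sit at the limit. The step of an at least 1.2-fold lower number from compound 2 to compound 3 (0.09 log units; that floor lies within the scatter) is expected to be small, if anything toward smaller numbers, and not clearly beyond the scatter. Compound 3 is therefore estimated at 8000 nM, with a plausible span from 1500 nM to 30000 nM, and a real chance that the assay again reports only a limit.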

Compound 3, half-maximal effective concentration: 790 nM
The estimate for compound 3 lay 10-fold (1.01 log units) above the measured number; measured number below the stated range.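

In this assay, within the data shown here, the substituent on the amine nitrogen in a ring is the first place where a change yields a real number, with compound 3 at 790 nM. Putting (oxolan-2-yl)carbonyl in place of cyclohexyl on that nitrogen gives an at least 12-fold lower number from compound 2 to compound 3 (1.10 log units; beyond the scatter), so this position can bring a compound on this core from the edge of the assay into its measurable range, something the two earlier compounds, both stuck at the limit, could not show. Compound 2 gives > 10000 nM, which is a limit of the assay and not a number, so the true size of the step stays unknown and it may be larger than the printed floor: the limit of > 10000 nM in this assay, at which 2 of the 3 values shown sit.

The carbonyl and the five-membered ring with its oxygen entered together in this one change, and the compounds shown cannot say which of them carries the step, or whether both are needed. A cyclohexylcarbonyl group on the same nitrogen would keep the six-membered carbon ring and add only the carbonyl, and an acetyl group would keep the carbonyl with no ring at all, so either one would help to separate the two parts.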